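Clearance of the Shared Core after Substitution on the Aromatic Nitrogen

This account rests on a few compounds, and the source may have more. Where it says the series, first, only, none or still open, it means among the compounds named here.

Measured compounds:
compound 1, `CCCCN(C(=O)c1ccc(C(F)(F)F)cc1)c1nnc(-c2cccc3[nH]ccc23)s1`: 43.2 uL/min
compound 2, `CCCCN(C(=O)c1ccc(C(F)(F)F)cc1)c1nnc(-c2ccc(F)c3[nH]ccc23)s1`: 43 uL/min
compound 3, `CCCCN(C(=O)c1ccc(C(F)(F)F)cc1)c1nnc(-c2ccc(CN(C)C)cc2)s1`: 539 uL/min

These three compounds were run in an ADME assay on microsomes from liver (Rattus norvegicus) for metabolic stability, read by LC-MS, tested at 0.5 uM; on this read-out higher numbers stand for fast clearance and lower numbers for slow clearance. Compound 1 stands second highest of the three, with compound 2 nearest to it and compound 3 furthest away. The step of a 1.0-fold lower number from compound 1 to compound 2 (0.00 log units; within the scatter) comes from a fluoro in place of hydrogen on an aromatic carbon and lies within the scatter. The step of a 12-fold higher number from compound 1 to compound 3 (1.10 log units; beyond the scatter) is large and comes from 4-((dimethylamino)methyl)phenyl in place of 1H-indol-4-yl on an aromatic carbon.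

Compound 4, `CCCCN(C(=O)c1ccc(C(F)(F)F)cc1)c1nnc(-c2cccc3c2ccn3CCC(=O)O)s1`, has not yet been measured in this assay. It differs from compound 1 by 2-carboxyethyl in place of hydrogen on an aromatic nitrogen. Neither measured step touches this position: one alters an aromatic carbon of the indole ring, the other exchanges the whole indole for a different ring. Going by the values given here, no measured pair therefore bears directly on the change, and the data give no ground to expect a step beyond the scatter in either direction. The author estimates a step of a 1.1-fold lower number from compound 1 to compound 4 (0.03 log units; within the scatter) for compound 4. Compound 4 is expected to give about 40 uL/min in this assay, within a range from 15 uL/min to 120 uL/min.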

Compound 4, intrinsic clearance in a liver preparation (reported as CLH), per the amount of preparation that the assay uses: 80.6 uL/min
Compound 4: middle estimate off by 2.0-fold (0.30 log units), on the low side, within the range that was stated.
By their numbers in this assay, from the lowest: compounds 2, 1 and 4 (each within the scatter of the next); then compound 3.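

In this assay, going by these compounds alone, the step of a 1.9-fold higher number from compound 1 to compound 4 (0.27 log units; within the scatter) is the first reading at the aromatic nitrogen of the five-membered ring, a place that neither the fluoro change nor the exchange of the whole ring system touched. It shows that 2-carboxyethyl in place of hydrogen on this nitrogen, a change that adds a chain with a carboxylic acid at its end to the core of compound 1, leaves the clearance number within the usual scatter of repeated measurements, so this single change gives no clear shift at this position. Nothing in hand explains the number of compound 4, and no supporting measurement bears on this result.

From the compounds shown here alone, what a shorter or longer chain ending in a carboxylic acid, a methyl ester of that acid, or a chain ending in an amine would do on the same nitrogen remains open. Also open is whether the step would look the same on the core of compound 2, as 2-carboxyethyl appears among these compounds only on the core of compound 1.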